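A few compounds are considered here, and "the series" means these few. Any claim that something is new, unique, unknown or untested is made for them only; others in the source may bear on it.

Measured compounds:
- compound 1, `Cn1c(=O)c2c(nnn2C2CCCCC2)n(C)c1=O`, 23000 nM
- compound 2, `Cn1c(=O)c2c(nnn2C2CCCCC2O)n(C)c1=O`, 114000 nM
- compound 3, `CCCn1c(=O)c2nn(C3CCCCC3)nc2n(CCC)c1=O`, 1600 nM

All three were tested in an assay on cell membranes from brain for displacement of a labelled ligand from adenosine receptor A1 (Bos taurus); on this read-out higher numbers stand for weaker inhibition and lower numbers for stronger inhibition. Compound 1 and compound 2 share one core and differ in a single spot: hydroxy in place of hydrogen on a saturated ring carbon. That change is measured and gives a 5.0-fold higher number from compound 1 to compound 2 (0.70 log units; beyond the scatter), so adding the hydroxy weakened binding on this pair. Compound 3 has a different core from compound 1, and the difference between the two cores is not broken down here; what the numbers show is that in this assay compound 3 gives 1600 nM, while compound 1 gives 23000 nM, so compound 3 shows the strongest inhibition of the three measured.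

Compound 4, `CCCn1c(=O)c2nn(C3CCCCC3O)nc2n(CCC)c1=O`, has not yet been measured. It relates to compound 3 exactly as compound 2 relates to compound 1: hydroxy in place of hydrogen on a saturated ring carbon. Since the place of the change is the same, this is the same change seen once before, now made on the stronger-binding core.

Within the data shown here, the expectation rests on a single earlier example, so it is uncertain, but the only guide is that the step of a 5.0-fold higher number from compound 1 to compound 2 (0.70 log units; beyond the scatter) weakened binding modestly. Compound 4 is therefore estimated to bind more weakly than compound 3, with an expected step of a 5.0-fold higher number from compound 3 to compound 4 (0.70 log units; beyond the scatter). In this assay compound 4 is expected to give about 8000 nM, with a likely range from 2500 nM to 30000 nM.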

Compound 4, inhibition constant: 1400 nM
Estimate against measurement, compound 4: 5.7-fold (0.76 log units) above, outside the stated range (below it).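

In this assay, the step for hydroxy in place of hydrogen on the second core is a 1.1-fold lower number from compound 3 to compound 4 (0.06 log units; within the scatter), so the two compounds cannot be told apart on this read-out. The step seen on the first core therefore did not carry over at the same size to the second, and a change measured on one core is not a safe guide to its size on the other here: the same change on two cores in this assay, a 5.0-fold higher number (0.70 log units; beyond the scatter) from compound 1 to compound 2 and a 1.1-fold lower number (0.06 log units; within the scatter) from compound 3 to compound 4, 5.7-fold (0.75 log units) apart, beyond the scatter of two such steps

This does not show which of the differences between the two cores lies behind the gap, and two pairs are too few to give a rule for any further core in this series.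

As far as these compounds go, it remains open how other groups in place of that hydrogen on the cyclohexyl ring, such as an amine, a methoxy group or a carboxylic acid, would compare on the two cores. Among these compounds, it is also open whether the hydroxy would give a step like the one on compound 1 and compound 2 or the one on compound 3 and compound 4 on a core carrying butyl chains instead of the propyl chains of compound 3.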